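Hydroxy to ethoxy on the aromatic ring of compound 2

The compounds below may be only part of what the source reports. "The series", "measured", "known", "first", "only" and "open" are said of these compounds alone.

Measured so far in a functional assay (mast cells) for inhibition, with Rattus norvegicus as the target (on this read-out higher numbers stand for an effect only at larger amounts of compound and lower numbers for an effect already at smaller amounts), for two compounds:
- compound 1 `CC1CC/C(=N\Nc2ccc(F)cc2)c2ncc(C(=O)O)c(=O)n21` gives 1200 nM
- compound 2 `CC1CC/C(=N\Nc2ccc(O)cc2)c2ncc(C(=O)O)c(=O)n21` gives 1300 nM

Among the measured compounds shown here, the only measured change, hydroxy in place of fluoro on an aromatic carbon, gives a 1.1-fold higher number from compound 1 to compound 2 (0.03 log units; within the scatter) and lies within the scatter. Compound 2 (1300 nM) therefore cannot be told apart from compound 1, and the two stand level on the numbers shown.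

Compound 3 `CCOc1ccc(N/N=C2\CCC(C)n3c2ncc(C(=O)O)c3=O)cc1` has not yet been measured. It differs from compound 2 by ethyl in place of hydrogen on an oxygen on an aromatic ring, which is hydroxy to ethoxy (ethyl in place of hydrogen on an oxygen on an aromatic ring). For the measured compounds named here, no measured step alters that oxygen, so the one step available bears on this change only indirectly. That step is small, and a single pair is thin evidence. No step beyond the scatter is therefore expected in this assay, although the range must stay wide. The estimated step is a 1.3-fold lower number from compound 2 to compound 3 (0.11 log units; within the scatter) in either direction within that range. For compound 3 the estimated value is 1000 nM with an expected range from 350 nM to 3000 nM in this read-out.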

Compound 3, half-maximal effective concentration: 17600 nM
For compound 3 the middle estimate is 18-fold (1.25 log units) below the measured one, outside the stated range (above it).
By their numbers in this assay, from the lowest: compounds 1 and 2 (each within the scatter of the next); then compound 3.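

In this assay, the earlier pair showed no measurable difference at this place on the aromatic ring, with a 1.1-fold higher number from compound 1 to compound 2 (0.03 log units; within the scatter), but ethyl in place of hydrogen on the oxygen gives a 14-fold higher number from compound 2 to compound 3 (1.13 log units; beyond the scatter), so this position is not indifferent to what it carries. Ethoxy in place of fluoro gives a step of similar size, a 15-fold higher number from compound 1 to compound 3 (1.17 log units; beyond the scatter), so compound 3 stands apart from both earlier compounds, whichever of them serves as the reference. Nothing available accounts for this step.

The compounds shown leave open whether methoxy would stand with compound 2 or with compound 3, and so whether the step appears as soon as a carbon chain sits on the oxygen or depends on the ethyl itself. They also leave open whether a longer chain such as propoxy would push the number higher still, and whether an amine on the same aromatic carbon would stand level with compound 1 and compound 2.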